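From compound 3 to compound 4: losing a methyl

The compounds below may be only part of what the source reports. "The series", "measured", "known", "first", "only" and "open" are said of these compounds alone.

Measured in a physicochemical assay for solubility (on this read-out lower numbers stand for lower solubility and higher numbers for higher solubility), so far:
compound 1 `CNC(=O)c1cc(C(=O)N[C@H]2[C@@H]3C[C@H](O)C[C@@H]32)cc2c1OC[C@@]2(C)c1ccccc1` gives >= 151 ug/mL as a limit
compound 2 `CNC(=O)c1cc(C(=O)N[C@H]2CC[C@H](O)CC2)cc2c1OC[C@@]2(C)c1ccccc1` gives >= 161 ug/mL as a limit
compound 3 `CNC(=O)c1cc(C(=O)N[C@H]2C[C@@H]2C)cc2c1OC[C@@]2(C)c1ccccc1` gives 3 ug/mL as a number

Among the measured compounds shown here, compound 3 stands at 3 ug/mL and is the only compound of the three with a number. Compound 4 `CNC(=O)c1cc(C(=O)NC2CC2)cc2c1OC[C@@]2(C)c1ccccc1` has not yet been measured. The change to it is hydrogen in place of methyl on a saturated ring carbon that is, hydrogen in place of methyl on a saturated ring carbon, so that 2-methylcyclopropyl becomes cyclopropyl. For the measured compounds named here, no measured step makes this exact change. The nearest are an at least 50-fold lower number from compound 1 to compound 3 (1.70 log units; beyond the scatter) and an at least 53-fold lower number from compound 2 to compound 3 (1.72 log units; beyond the scatter) and both are large, but each exchanges the whole group on the amide-type nitrogen. They say little about a single methyl. The estimate therefore stays close to compound 3 at 3 ug/mL in this assay and no step beyond the scatter is expected. The expected step is a 1.7-fold higher number from compound 3 to compound 4 (0.22 log units; within the scatter) on this estimate. Compound 4 is estimated at 5 ug/mL with a range of 2 ug/mL to 20 ug/mL expected.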

Compound 4, solubility: >= 138 ug/mL
Compound 4 ended at the assay's limit (the forecaster's own chance of this, stated with the estimate: 5%); middle value at least 27-fold (1.44 log units) away from the limit.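

In this assay, the exchange of a single methyl for hydrogen on a saturated ring carbon comes with a step as large as those that earlier came only with an exchange of the whole group on the amide-type nitrogen: an at least 46-fold higher number from compound 3 to compound 4 (1.66 log units; beyond the scatter). As far as these compounds go, compound 4 is reported only as a limit, so the full size of this step stays unknown: the limit of >= 138 ug/mL in this assay, at which 1 of the 4 values shown sits. Compound 4 has cyclopropyl and no hydroxy-bearing group, yet it too ends at a limit like compound 1 and compound 2, and the steps from those two to compound 4 cannot be read, with limits at both ends.

Among the compounds shown here, compound 3 remains the only compound with a number. From the compounds shown here alone, whether an ethyl group in place of the methyl, or a cyclobutyl ring in place of cyclopropyl, would stand with compound 3 or with compound 4 stays open.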